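From 2-chloropyridin-3-yl to 2-chlorophenyl in compound 1

The source may report more compounds than this note shows. Statements on the series, on what has been measured and on what is new or still open speak of the compounds shown alone.

Compound 1 (`Cc1nc(C)c(C(=O)Nc2ccc(F)c(-c3nc4ncc(-c5cccnc5Cl)cn4n3)c2)o1`) has a solubility of 3840 nM
Compound 2 (`O=C(Nc1ccc(F)c(-c2nc3ncc(-c4cccnc4F)cc3[nH]2)c1)N1CCCC1`) has a solubility of 9300 nM

For the measured compounds named here, both numbers come from a physicochemical assay for solubility, read by LC-MS, in phosphate buffer, at pH 7.4, tested at 50 uM (a lower number here means a less soluble compound, a higher number a more soluble compound), and are the only measurements so far. Compound 1 has the lower number of the two, and its gap to compound 2 lies beyond the usual scatter of repeated measurements. The two structures differ in more than one place, however, so this gap cannot be tied to any single group.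

Compound 3 (`Cc1nc(C)c(C(=O)Nc2ccc(F)c(-c3nc4ncc(-c5ccccc5Cl)cn4n3)c2)o1`) is compound 1 with one change, 2-chlorophenyl in place of 2-chloropyridin-3-yl on an aromatic carbon. The rest of the structure stays the same. Going by the values given here, no pair of measured compounds differs in just one place, so the data offer no direct guide to this change, and any forecast is a judgement with a wide range. A downward step in this assay is expected, estimated as a 2.6-fold lower number from compound 1 to compound 3 (0.41 log units; beyond the scatter) and of moderate size, although a result within the scatter of compound 1 would not be surprising. Compound 3 is therefore estimated at 1500 nM (expected range 500 nM to 3800 nM).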

Compound 3, solubility: 1980 nM
Compound 3: middle estimate off by 1.3-fold (0.12 log units), on the low side; low and high end bracket the measured number.
By their numbers in this assay, from the lowest: compounds 3 and 1 (each within the scatter of the next); then compound 2.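

In this assay, putting 2-chlorophenyl in place of 2-chloropyridin-3-yl on this aromatic carbon gives a 1.9-fold lower number from compound 1 to compound 3 (0.29 log units; within the scatter). For the compounds shown here, this is the first comparison that isolates a single group, and it shows that exchanging the ring nitrogen of this substituent for carbon, while the chlorine and the rest of the structure stay the same, leaves the read-out within the usual scatter of repeated measurements, so this pair gives no firm sign that the ring nitrogen matters to the read-out at this position. No measurement at hand bears on what lies behind this small step.

As far as these compounds go, the two groups compared here are both chlorine-bearing six-membered aromatic rings, so it remains open how this assay would respond to a different kind of group on the same carbon, such as a morpholine, a primary amine or a carboxylic acid. From the compounds shown here alone, it also remains open whether the same exchange would give a step of similar size on a different core, and whether repeat measurements of this pair would resolve any real difference.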